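Fluorine Enters the Oxadiazole of Compound 3

This account rests on a few compounds, and the source may have more. Where it says the series, first, only, none or still open, it means among the compounds named here.

Compound 3 `Cc1nc(S(C)(=O)=O)ccc1Oc1ncnc(OC2CCN(C(=O)c3noc(C(C)C)n3)CC2)c1F` gives 81% in a functional assay on isolated protein for inhibition of Glucose-dependent insulinotropic receptor (Rattus norvegicus), read by HTRF and cAMP accumulation (a higher number here means a larger maximal response, a lower number a smaller maximal response), the second highest of three numbers, though all three lie within the scatter of one another: compound 1 `Cc1nc(S(C)(=O)=O)ccc1Oc1ncnc(OC2CCN(C(=O)O[C@@H](C)CF)CC2)c1F` gives 84% and compound 2 `Cc1nc(S(C)(=O)=O)ccc1Oc1ncnc(OC2CCN(C(=O)SC3(C)CC3)CC2)c1F` gives 77%. The three measured steps, each a swap on the carbonyl carbon, were a number 7 percentage points lower from compound 1 to compound 2 (within the scatter), a number 3 percentage points lower from compound 1 to compound 3 (within the scatter) and a number 4 percentage points higher from compound 2 to compound 3 (within the scatter), none beyond the scatter. Compound 4 `Cc1nc(S(C)(=O)=O)ccc1Oc1ncnc(OC2CCN(C(=O)c3nc(C(C)(C)F)no3)CC2)c1F` differs from compound 3 by a group of 9 heavy atoms (5 carbon, 2 nitrogen, 1 oxygen, 1 fluorine; one five-membered aromatic ring with 3 hetero atoms) in place of a group of 8 heavy atoms (5 carbon, 2 nitrogen, 1 oxygen; one five-membered aromatic ring with 3 hetero atoms), on a carbonyl carbon. Among the compounds with values here, no measured pair shows exactly this fluorine addition, but every change so far at that carbonyl carbon left this assay flat. The step to compound 4 is therefore expected to be a number 1 percentage points lower from compound 3 to compound 4 (within the scatter). Compound 4 is estimated at 80%, with a range from 70% to 90%.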

Compound 4, largest response reached (reported as efficacy), in percent of the reference or control that the assay uses: 84%
The estimate for compound 4 lay 4 percentage points below the measured number; low and high end bracket the measured number.
By their numbers in this assay, from the lowest: compounds 2, 3, 1 and 4 (each within the scatter of the next).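

In this assay, the fluorine-bearing oxadiazole group gave a number 3 percentage points higher from compound 3 to compound 4 (within the scatter), so this change on the carbonyl carbon produced no step beyond the scatter. The comparisons with the other groups on that carbon, a number 7 percentage points higher from compound 2 to compound 4 (within the scatter) and no change at the digits printed from compound 1 to compound 4 (within the scatter), extend this flat picture to compound 4. No supporting data explain this tolerance.

Going by these compounds, it remains open whether a trifluoromethyl group in place of the fluorine-bearing chain would also stay within the scatter. The same applies to an amine or a carboxylic acid on the oxadiazole.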